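The compounds below may be only part of what the source reports. "The series", "measured", "known", "first", "only" and "open" are said of these compounds alone.

Values in a functional assay on QGY7701 cells (Homo sapiens) for cytotoxicity, read by MTT assay, with a stated time of 48 h (on this read-out higher numbers stand for weaker inhibition and lower numbers for stronger inhibition), for the three measured compounds
Compound 1 `O=c1ccoc2cc(OCc3cn(Cc4ccc(Cl)cc4)nn3)ccc12` gives 41700 nM
Compound 2 `Cc1ccccc1Cn1cc(COc2ccc3c(=O)ccoc3c2)nn1` gives > 100000 nM (a limit of the assay, not a number)
Compound 3 `O=c1ccoc2cc(OCc3cn(Cc4ccc(Cl)cc4Cl)nn3)ccc12` gives 13300 nM

Of the two true numbers, compound 1 holds the higher, and the gap is a 3.1-fold lower number from compound 1 to compound 3 (0.50 log units; beyond the scatter). Compound 4 `CC(C)(C)c1ccc(Cn2cc(COc3ccc4c(=O)ccoc4c3)nn2)cc1` carries tert-butyl in place of chloro on an aromatic carbon, para to a large group (tert-butyl in place of chloro on an aromatic carbon). Among the measured compounds shown here, no measured step makes this exchange. The closest steps run in opposite directions: 2-methylphenyl in place of 4-chlorophenyl gave an at least 2.3-fold higher number from compound 1 to compound 2 (0.37 log units; beyond the scatter) and 2,4-dichlorophenyl in place of 2-methylphenyl gave an at least 7.5-fold lower number from compound 2 to compound 3 (0.87 log units; beyond the scatter). No step beyond the scatter is therefore expected in this assay, and the estimated step is a 1.1-fold higher number from compound 1 to compound 4 (0.03 log units; within the scatter). The expected value for compound 4 is 45000 nM with an estimated range from 15000 nM to 100000 nM.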

Compound 4, half-maximal inhibitory concentration: > 100000 nM
Compound 4: only a limit was reported; the forecaster's own chance of this, stated with the estimate: 25%; middle value at least 2.2-fold (0.34 log units) from the limit.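

In this assay, tert-butyl in place of chloro on an aromatic carbon, para to a large group, gives an at least 2.3-fold higher number from compound 1 to compound 4 (0.37 log units; beyond the scatter). This is the first exchange shown that changes only this position, and the four carbons of tert-butyl do not keep the value that the single chlorine gives. Going by these compounds, the value of compound 4 is a limit of the assay and not a number, so the true size of the step stays open: the limit of > 100000 nM in this assay, at which 2 of the 4 values shown sit. The compounds shown leave open whether fluoro, methoxy or an amine at this position would hold or improve on the value of compound 1.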